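A few compounds are considered here, and "the series" means these few. Any claim that something is new, unique, unknown or untested is made for them only; others in the source may bear on it.

Measured compounds in a functional assay on SMMC-7721 cells (Homo sapiens) for cytotoxicity, read by MTT assay, with a stated time of 72 h; a lower number here means a stronger inhibitor, a higher number a weaker inhibitor:
compound 1 `COc1cc2c(Oc3ccc(NC(=O)c4cc(-c5ccccc5)nc5ccccc45)cc3F)ccnc2cc1OCCCN1CCCCC1`, 290 nM;
compound 2 `COc1cc2c(Oc3ccc(NC(=O)c4cc(-c5ccc(F)cc5)nc5ccccc45)cc3F)ccnc2cc1OCCCN1CCCCC1`, 74 nM;
compound 3 `COc1cc2c(Oc3ccc(NC(=O)c4cc(-c5cccc(Cl)c5)nc5ccccc45)cc3F)ccnc2cc1OCCCN1CCCCC1`, 30 nM.

Compound 3 gives the lowest number of the three; the steps of a 9.7-fold lower number from compound 1 to compound 3 (0.99 log units; beyond the scatter) and a 2.5-fold lower number from compound 2 to compound 3 (0.39 log units; beyond the scatter) both exceed the scatter, as does a 3.9-fold lower number from compound 1 to compound 2 (0.59 log units; beyond the scatter). All three steps concern the aryl group on the shared core, not the saturated ring.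

Compound 4 `COc1cc2c(Oc3ccc(NC(=O)c4cc(-c5cccc(Cl)c5)nc5ccccc45)cc3F)ccnc2cc1OCCCN1CCC(C)CC1` differs from compound 3 by methyl in place of hydrogen on a saturated ring carbon. For the measured compounds named here, no measured pair in this assay touches that ring, so nothing here bears on the change; the default expectation is a step from compound 3 to compound 4 of no size beyond the scatter, no change at the digits printed from compound 3 to compound 4 (within the scatter). Compound 4 is therefore estimated at 30 nM in this assay, with a range from 12 nM to 75 nM.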

Compound 4, half-maximal inhibitory concentration: 80 nM
The estimate for compound 4 lay 2.7-fold (0.43 log units) below the measured number, outside the stated range (above it).
By their numbers in this assay, from the lowest: compound 3; then compounds 2 and 4 (each within the scatter of the next); then compound 1.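

In this assay, the saturated ring is not a silent position: 4-methylpiperidin-1-yl in place of piperidin-1-yl gives a weaker compound (a 2.7-fold higher number from compound 3 to compound 4 (0.43 log units; beyond the scatter)). This is the only step shown at that ring, and it shows that one methyl, three ring bonds from the ring nitrogen, is enough to move the number beyond the scatter. Nothing shown gives a reason for the step.

Open, going by these compounds, is whether an ethyl or hydroxyl group on the same ring carbon, or morpholine in place of the piperidine, would move the number the same way. Also open, on these data alone, is whether the step holds with the 4-fluorophenyl group of compound 2.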